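From piperidin-4-yl to an open chain on the oxygen

The source may hold more compounds than are shown below. What is called first, only, known or untested is meant among the compounds shown, and "the series" means these compounds.

Compound 1 `CC(C)(O)CNCCCOc1ccc([C@H]2CC[C@]3(CC2)OOC2(O3)C3CC4CC(C3)CC2C4)cc1` and compound 2 `c1cc([C@H]2CC[C@]3(CC2)OOC2(O3)C3CC4CC(C3)CC2C4)ccc1OC1CCNCC1` share a core and differ only in the group on an oxygen on an aromatic ring. In an ADME assay on the whole organism (strain FVB) for pharmacokinetics, with Mus musculus as the target, read by LC-MS, at a dose of 30 mg/kg by the oral route (a lower number here means less compound in the circulation, a higher number more compound in the circulation at the dose given), compound 2 reaches a maximal plasma concentration of 810 nM and compound 1 reaches 1210 nM in the same test. Among the measured compounds shown here, these two numbers lie within the usual scatter of each other, so compound 2 cannot be ranked against its only neighbour.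

Compound 3 `CC(C)(CN)Oc1ccc([C@H]2CC[C@]3(CC2)OOC2(O3)C3CC4CC(C3)CC2C4)cc1` has not yet been measured. It brings 1-(aminomethyl)-1-methylethyl in place of piperidin-4-yl on an oxygen on an aromatic ring and so has no ring in that group. For the measured compounds named here, one measured step bears on this site: a 1.5-fold lower number from compound 1 to compound 2 (0.17 log units; within the scatter) is the change there, and it stays within the scatter. Going by the values given here, that is thin evidence, since no measured compound carries the new group. Even so, no change beyond the scatter is expected in this assay for this swap. The estimated 1.1-fold higher number from compound 2 to compound 3 (0.05 log units; within the scatter) is expected to stay within the scatter too. For compound 3 the estimate is 900 nM with an expected range from 300 nM to 2700 nM in this test.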

Compound 3, maximal plasma concentration: 529 nM
Compound 3: the middle estimate sits 1.7-fold (0.23 log units) above what was measured, and the stated range covers the measured number.
By their numbers in this assay, from the lowest: compounds 3, 2 and 1 (each within the scatter of the next, the first and the last beyond it).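

In this assay, among the compounds shown here, the swap to 1-(aminomethyl)-1-methylethyl produces the first step at this position that lies beyond the scatter, with a 2.3-fold lower number from compound 1 to compound 3 (0.36 log units; beyond the scatter), so the group on this oxygen can matter for the amount of compound reaching the circulation. That separation is between two groups that both lack a ring, while piperidin-4-yl cannot be told apart from the new group, given a 1.5-fold lower number from compound 2 to compound 3 (0.19 log units; within the scatter), so having a ring or not does not by itself sort these three compounds. No measurement here bears on why the two open chains separate.

A plain 2-aminoethyl group would test whether the short chain needs its branching, and a chain ending in a carboxylic acid would show what happens when the amine is replaced altogether. The compounds shown also leave open whether the modest gap between the two open chains comes from the chain length, from the hydroxyl group or from the way the amine is substituted, as these differ together in a single swap.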